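Cyano for Methoxy on the Demethylated Amine Core

A few compounds are considered here, and "the series" means these few. Any claim that something is new, unique, unknown or untested is made for them only; others in the source may bear on it.

Compound 1, `CNCCN(C)Cc1ccc(-c2cccc(OC)c2)o1`, is tested in an assay on cells for inhibition of protein arginine N-methyltransferase 1 (Homo sapiens), read by scintillation counting, with stated times of 15 min and 60 min, tested at 9 uM (a higher number here means more inhibition at the concentration tested (going by the name of the read-out), a lower number less inhibition), and gives 37%. Compound 2, `CNCCN(C)Cc1ccc(-c2cccc(C#N)c2)o1`, carries cyano in place of methoxy on an aromatic carbon; in this assay compound 2 gives 33%, so that a number 4 percentage points lower from compound 1 to compound 2 (within the scatter). Compound 3, `COc1cccc(-c2ccc(CN(C)CCN)o2)c1`, differs from compound 1 by hydrogen in place of methyl on an amine nitrogen; in this assay compound 3 gives 24%, and a number 13 percentage points lower from compound 1 to compound 3 (beyond the scatter). Compound 4, `CN(CCN)Cc1ccc(-c2cccc(C#N)c2)o1`, has not yet been measured. It stands to compound 3 exactly as compound 2 stands to compound 1: the same change, (cyano in place of methoxy on an aromatic carbon), at a place described in identical words. Compound 4 is expected to follow compound 3 with a step of a number 4 percentage points lower from compound 3 to compound 4 (within the scatter), because a number 4 percentage points lower from compound 1 to compound 2 (within the scatter) lay within the scatter. Compound 4 is thus estimated at 20% in this assay, with a likely range from 8% to 32%.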

Compound 4, a percentage reported as inhibition, at one concentration (the size of the read-out at that concentration, not a potency): 38%
Compound 4: the middle estimate sits 18 percentage points below what was measured; the measured number lies above the stated range.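

In this assay, cyano in place of methoxy on an aromatic carbon did not carry over from one core to the other, and on the core of compound 3 the step was a number 14 percentage points higher from compound 3 to compound 4 (beyond the scatter): the same change on two cores in this assay, a number 4 percentage points lower (within the scatter) from compound 1 to compound 2 and a number 14 percentage points higher (beyond the scatter) from compound 3 to compound 4, 18 percentage points apart, beyond the scatter of two such steps. Hydrogen in place of methyl on an amine nitrogen did not carry over either, and with the cyano group present the step was a number 5 percentage points higher from compound 2 to compound 4 (within the scatter): the same change on two cores in this assay, a number 13 percentage points lower (beyond the scatter) from compound 1 to compound 3 and a number 5 percentage points higher (within the scatter) from compound 2 to compound 4, 18 percentage points apart, beyond the scatter of two such steps. This shows that the outcome of each change depended on the other place in these four compounds, but it does not show why, or whether this holds beyond them.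

Going by these compounds, it remains open how a carboxylic acid or a trifluoromethyl group would behave in place of the cyano group. On these data alone, it also remains open whether a longer chain on the amine would show the same dependence.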